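Aryl ketone exchange on the enone series

This account rests on a few compounds, and the source may have more. Where it says the series, first, only, none or still open, it means among the compounds named here.

Compound 2 `COc1ccc(-c2cc3ccccc3nc2/C=C/C(=O)c2ccc(O)cc2)cc1` gives 6930 nM in a functional assay on NCI-H460 cells (Homo sapiens) for antiproliferative activity, read by XTT assay, with a stated time of 72 h (on this read-out higher numbers stand for weaker inhibition and lower numbers for stronger inhibition), and stands level with compound 1 `COc1ccc(-c2cc3ccccc3nc2/C=C/C(=O)c2ccccc2)cc1`, which gives 6670 nM, the two lying within the scatter of each other. Compound 3 `COc1ccc(-c2cc3ccccc3nc2/C=C/C(=O)c2ccc(Br)s2)cc1` carries the change (5-bromothiophen-2-yl in place of 4-hydroxyphenyl on a carbonyl carbon). Within the data shown here, of the measured steps only a 1.0-fold higher number from compound 1 to compound 2 (0.02 log units; within the scatter) touches this position, and it is flat; the ring exchange itself has no precedent among the measured pairs. The expectation is accordingly no step beyond the scatter, a 1.1-fold lower number from compound 2 to compound 3 (0.03 log units; within the scatter), with wide uncertainty. Compound 3 is estimated at 6500 nM, range 2500 nM to 17000 nM.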

Compound 3, half-maximal inhibitory concentration: 5170 nM
For compound 3 the middle estimate is 1.3-fold (0.10 log units) above the measured one, within the range that was stated.
By their numbers in this assay, from the lowest: compounds 3, 1 and 2 (each within the scatter of the next).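

Exchange on the carbonyl carbon now extends from a substituent on the phenyl ring to the whole ring. In this assay, 5-bromothiophen-2-yl in place of 4-hydroxyphenyl gives a 1.3-fold lower number from compound 2 to compound 3 (0.13 log units; within the scatter), and in place of phenyl it gives a 1.3-fold lower number from compound 1 to compound 3 (0.11 log units; within the scatter). The position therefore takes a five-membered aromatic ring bearing bromine with the numbers staying level, and no measurement on hand explains this.

Still open, as far as these compounds go, is whether an amine, a carboxylic acid or a longer chain on this carbonyl carbon would give a step beyond the scatter.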